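This account rests on a few compounds, and the source may have more. Where it says the series, first, only, none or still open, it means among the compounds named here.

Compound 3 `O=C(O)[C@@H]1NC[C@H](O)[C@@H](O)[C@H]1O` stands highest of the three compounds measured in an assay on isolated protein for inhibition of cytosolic endo-beta-N-acetylglucosaminidase (Homo sapiens), tested at 1000 uM (on this read-out lower numbers stand for less inhibition and higher numbers for more inhibition at the one concentration tested (going by the name of the read-out)), where compound 3 gives 42%. Compound 1 `O=C(O)[C@H]1NC[C@@H](O)[C@H](O)[C@H]1O` gives 6.3% and compound 2 `O=C(O)[C@@H]1NC[C@@H](O)[C@@H](O)[C@@H]1O` gives 2.1%; the step of a number 4.2 percentage points lower from compound 1 to compound 2 (within the scatter) is within the scatter. Compound 4 `O=C(O)[C@@H]1NC[C@@H](O)[C@H](O)[C@H]1O` has not yet been measured. The change from compound 3 to compound 4 is the two compounds have the same atoms and bonds and differ only in configuration as drawn: 2 of 4 stereo elements differ; a stereocentre at a saturated ring carbon is drawn S in compound 3 and R in compound 4; a stereocentre at a saturated ring carbon is drawn R in compound 3 and S in compound 4. Within the data shown here, the steps that bear on it are the two configurational ones, a number 39.9 percentage points higher from compound 2 to compound 3 (beyond the scatter) and a number 35.7 percentage points higher from compound 1 to compound 3 (beyond the scatter), both large, showing that redrawn stereocentres can swing the read-out widely the fact that compounds 2 and 3 differ only in the configuration as drawn (the fact that compounds 1 and 3 differ only in the configuration as drawn), although the pair compound 1 and compound 2 did not. Among the measured compounds shown here, compound 3 holds the only high number, so a further change of two stereocentres is expected to lower inhibition, giving a number 30 percentage points lower from compound 3 to compound 4 (beyond the scatter). Compound 4 is therefore estimated at 12%, between 0% and 40%.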

Compound 4, a percentage reported as inhibition, at one concentration (the size of the read-out at that concentration, not a potency): 50%
The estimate for compound 4 lay 38 percentage points below the measured number; measured number outside the range, above it.
By their numbers in this assay, from the lowest: compounds 2 and 1 (each within the scatter of the next); then compounds 3 and 4 (each within the scatter of the next).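

Two stereocentres can be redrawn with no clear effect in this assay, as the step of a number 8 percentage points higher from compound 3 to compound 4 (within the scatter) shows, so a high number is not confined to one arrangement. Yet redrawing two stereocentres elsewhere gives a number 47.9 percentage points higher from compound 2 to compound 4 (beyond the scatter), so the outcome depends on which stereocentres change. Among these compounds, a single stereocentre at a saturated ring carbon, the only difference in its pair, is enough for a number 43.7 percentage points higher from compound 1 to compound 4 (beyond the scatter).

The compounds shown leave open how the other arrangements of these stereocentres would read. They also leave open whether a hydroxymethyl group or a primary amide could replace the carboxylic acid and keep the inhibition.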